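The source may hold more compounds than are shown below. What is called first, only, known or untested is meant among the compounds shown, and "the series" means these compounds.

Measured compounds:
- compound 1, `N#CC1=C(N)OC(c2c[nH]c3ccccc23)=C(C#N)C1c1ccccc1F`: "not active" (no number reported)
- compound 2, `COc1cc(Br)c(C2C(C#N)=C(N)OC(c3c[nH]c4ccccc34)=C2C#N)cc1OC`: 18.5%
- compound 3, `N#CC1=C(N)OC(c2c[nH]c3ccccc23)=C(C#N)C1c1ccc(Br)cc1`: 14.2%

The shared core carries a 1H-indol-3-yl group, an amino group and two cyano groups, and the three compounds differ only in the aryl group on the saturated ring carbon. In a functional assay, tested at 50 ug/mL (on this read-out higher numbers stand for a stronger effect at the one concentration tested and lower numbers for a weaker effect), compound 1 gives "not active" (no number reported), a result with no number behind it. Compound 2 gives 18.5% in this assay. Compound 3, with its 4-bromophenyl group, gives 14.2% in this assay, which stands within the scatter of compound 2; the two numbers cannot be told apart, and compound 1 adds no number to set them against. Among the measured compounds shown here, no step between two measured compounds is on hand, so the size of any step in this assay is unknown from this set.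

Compound 4, `N#CC1=C(N)OC(c2c[nH]c3ccccc23)=C(C#N)C1c1ccc2ccccc2c1`, has not yet been measured. It differs from compound 3 by naphthalen-2-yl in place of 4-bromophenyl on a saturated ring carbon. Both measured numbers are modest and close to each other, so no step beyond the scatter is expected; the step of a number 0.8 percentage points higher from compound 3 to compound 4 (within the scatter) is the estimated outcome. For compound 4 in this assay the expected value is 15%, within 0% to 35%.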

Compound 4, a percentage reported as activity, at one concentration (the size of the read-out at that concentration, not a potency): "not active" (no number reported)
Compound 4: no number reported; the estimate stays without a comparison.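

Among the compounds shown here, compound 4 gives "not active" (no number reported) in this assay and so no step from compound 3 to compound 4 can be read. Nothing on hand bears on this result. The compounds shown leave open whether any change of the aryl group on the saturated ring carbon moves the read-out beyond the scatter.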